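A few compounds are considered here, and "the series" means these few. Any claim that something is new, unique, unknown or untested is made for them only; others in the source may bear on it.

Compound 1 `O=C(NC(=S)NCc1ccccc1)c1ccccc1` is the parent of this small set. In an assay on isolated protein for inhibition of polyamine deacetylase HDAC10 (Homo sapiens), read by fluorescence, tested at 100 uM (a higher number here means more inhibition at the concentration tested (going by the name of the read-out), a lower number less inhibition), compound 1 gives "not active" (no number reported), so no single number places it on the scale; a second entry shares this outcome. Two companions carry trifluoromethyl groups: compound 2 `O=C(NC(=S)NCc1cc(C(F)(F)F)cc(C(F)(F)F)c1)c1ccccc1` gives 10%, while compound 3 `O=C(NC(=S)NCc1ccc(C(F)(F)F)cc1)c1ccccc1` gives "not active" (no number reported). Compound 4 `O=C(NC(=S)NCc1ccccc1)c1ccccc1F` keeps the shared core of compound 1, and the one difference is fluoro in place of hydrogen on an aromatic carbon. Going by the values given here, no measured pair differing in a single place exists here, so compound 4 stands without a direct precedent. The change is expected to move this assay little, with no step beyond the scatter in either direction. Compound 4 is therefore estimated at 5%, within a range from 0% to 15%.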

Compound 4, a percentage reported as inhibition, at one concentration (the size of the read-out at that concentration, not a potency): 5%
The estimate for compound 4 equals the measured number at the digits printed; the range from low to high includes it.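

With compound 1 at "not active" (no number reported) and compound 4 at 5% in this assay no step can be read between them. What fluoro in place of hydrogen does to inhibition stays open, and nothing shown offers an explanation for either result.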